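Trifluoromethyl in place of carboxy on compound 1

This account rests on a few compounds, and the source may have more. Where it says the series, first, only, none or still open, it means among the compounds named here.

In an ADME assay on TZM cells (Homo sapiens) for cytotoxicity, read by XTT assay, with a stated time of 4 days (on this read-out higher numbers stand for lower toxicity in this test and lower numbers for higher toxicity in this test), compound 1 `Cc1cc(CCC#N)cc(C)c1Oc1cc(Nc2ccc(C#N)cc2)c(N)cc1C(=O)O` gives 14300 nM and compound 2 `Cc1cc(N)cc(C)c1Oc1cc(Nc2ccc(C#N)cc2)c(N)cc1C(F)(F)F` gives 15800 nM within the scatter of each other. Compound 3 `Cc1cc(CCC#N)cc(C)c1Oc1cc(Nc2ccc(C#N)cc2)c(N)cc1CO` returns > 23800 nM as a limit of the assay. Compound 4 `Cc1cc(CCC#N)cc(C)c1Oc1cc(Nc2ccc(C#N)cc2)c(N)cc1C(F)(F)F` is compound 1 with trifluoromethyl in place of carboxy on an aromatic carbon and has not been measured. Among the measured compounds shown here, the one measured step at that carbon is an at least 1.6-fold higher number from compound 1 to compound 3 (0.22 log units; that floor lies within the scatter) and it sets no size beyond the scatter. Compound 2 carries trifluoromethyl too and stands at 15800 nM in this read-out, so no shift beyond the scatter is expected. The expected change a 1.0-fold lower number from compound 1 to compound 4 (0.01 log units; within the scatter) in this assay stays within the scatter. For compound 4 the estimated value is 14000 nM with 6000 nM to 30000 nM as its expected range.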

Compound 4, half-maximal cytotoxic concentration: > 7100 nM
Compound 4: a limit, no number (the forecaster's own chance of this, stated with the estimate: 25%); the middle value is on the limit's open side.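

In this assay compound 4 gives > 7100 nM, a limit and not a number. Its steps from compound 1, compound 2 and compound 3 cannot be read. The compounds shown leave open whether trifluoromethyl in place of carboxy on an aromatic carbon changes this read-out beyond the scatter.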